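Aryl in place of tert-butyl on the oxamide nitrogen

The source may hold more compounds than are shown below. What is called first, only, known or untested is meant among the compounds shown, and "the series" means these compounds.

Three compounds share the core seen in compound 1 `CC(=O)Oc1ccc(/C=C/C(=O)Nc2ccc3c(c2)COC3=O)cc1OC(C)=O`, which in a functional assay on cells (T-cell, Mus musculus) for inhibition (on this read-out lower numbers stand for stronger inhibition and higher numbers for weaker inhibition), gives 180 nM. Compound 2 `Cc1ccccc1NC(=O)Nc1ccc2c(c1)COC2=O` gives 900 nM in this assay. Compound 3 `CC(C)(C)NC(=O)C(=O)Nc1ccc2c(c1)COC2=O` gives 3400 nM in this assay, the highest of the three numbers; compound 2 is nearest to it and compound 1 furthest, both gaps lying beyond the usual scatter. The two compounds with lower numbers both carry an aromatic ring on the amide-type nitrogen attached to the core, whereas compound 3 carries none.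

Compound 4 `COc1ccc(NC(=O)C(=O)Nc2ccc3c(c2)COC3=O)cc1` is not yet measured in this assay. Relative to compound 3 it differs in one place: 4-methoxyphenyl in place of tert-butyl on an amide-type nitrogen. Among the compounds with values here, no measured pair isolates this exact change, so the expectation rests on the aryl-bearing compounds alone. A step toward lower numbers in this assay beyond the scatter is expected a 3.8-fold lower number from compound 3 to compound 4 (0.58 log units; beyond the scatter), because compound 2 with an aromatic ring in the corresponding position gives 900 nM. Compound 4 is therefore estimated at 900 nM in this assay, with a range from 250 nM to 3000 nM.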

Compound 4, half-maximal inhibitory concentration: 153000 nM
The estimate for compound 4 lay 170-fold (2.23 log units) below the measured number, and the stated range ends below it.
By their numbers in this assay, from the lowest: compound 1; then compound 2; then compound 3; then compound 4.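

In this assay, 4-methoxyphenyl in place of tert-butyl on this amide-type nitrogen gives a 45-fold higher number from compound 3 to compound 4 (1.65 log units; beyond the scatter), so this position is highly sensitive to the group it carries. An aromatic ring on the nitrogen is therefore no general mark of lower numbers: compound 4 carries one and has the highest number of the four, against compound 1 and compound 2, which also carry one and have the two lowest. Nothing available explains the size of this step.

Still open, from the compounds shown here alone, is whether the aromatic ring or its methoxy group accounts for the step, which a plain phenyl or a cyclohexyl on this nitrogen would help to separate. Also open, going by these compounds, is how far the tert-butyl result extends to other groups here, such as isopropyl or a longer chain ending in an amine.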